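The source may report more compounds than this note shows. Statements on the series, on what has been measured and on what is new or still open speak of the compounds shown alone.

Measured compounds in a functional assay on HEL cells (Homo sapiens) for cytotoxicity; a lower number here means that less compound is tolerated, a higher number that more compound is tolerated:
compound 1 `CCCCCCCCc1cc2cn([C@H]3C[C@H](O)[C@@H](CO)O3)c(=O)nc2o1`: > 50000 nM
compound 2 `C=CCCCCCCc1cc2cn([C@H]3C[C@H](O)[C@@H](CO)O3)c(=O)nc2o1`: > 200000 nM
compound 3 `C#CCCCCCc1cc2cn([C@H]3C[C@H](O)[C@@H](CO)O3)c(=O)nc2o1`: > 200000 nM

All three entries are limits of the assay, not numbers. The series therefore has two reference points: the limit of > 200000 nM in this assay, at which 2 of the 3 values shown sit, and (the limit of > 50000 nM in this assay, at which 1 of the 3 values shown sits). Compound 3 has only a limit, > 200000 nM.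

Next in line is compound 4 `C#CCCCCCCc1cc2cn([C@H]3C[C@H](O)[C@@H](CO)O3)c(=O)nc2o1`. Its difference from compound 3 is propargyl in place of ethynyl on a saturated chain carbon, five bonds along the chain from an aromatic carbon.

Within the data shown here, three measured steps bear on this change: a step that the two limits leave unreadable from compound 2 to compound 3, a step that the two limits leave unreadable from compound 1 to compound 3 and a step that the two limits leave unreadable from compound 1 to compound 2. The second and third involve the same chain position or one close in kind, but none of the three has a readable size, so none gives a magnitude to carry over. No step beyond the scatter is therefore expected in this assay, and no direction is expected either. The expectation rests on compound 3 at > 200000 nM, which is a limit. Compound 4 is also expected to be reported most likely as a limit. The estimated step is a number no higher from compound 3 to compound 4 (the limit leaves the size open). For compound 4 the estimated value is 200000 nM, with an expected range of 60000 nM to 400000 nM.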

Compound 4, half-maximal cytotoxic concentration: > 200000 nM
Compound 4: no number, only a limit; the forecaster's own chance of this, stated with the estimate: 85%; the middle value lies on the limit itself.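

In this assay compound 4 gives > 200000 nM, which is a limit of the assay. Among these compounds, compound 1, compound 2 and compound 3 also carry only limits, so no step to compound 4 can be read. The compounds shown leave open whether any change to the chain shifts the tolerated concentration at all.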